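Methoxy replaced by ethyl on the sulfonamide aryl of compound 1

The source may report more compounds than this note shows. Statements on the series, on what has been measured and on what is new or still open speak of the compounds shown alone.

Compound 1 `COc1cccc(NS(=O)(=O)c2ccc(N3CCNC3=O)cc2)c1` gives 700 nM in a functional assay (CEM-VLB cells, Homo sapiens) for antiproliferative activity, read by sulforhodamine B assay, with a stated time of 48 h (a higher number here means a weaker inhibitor, a lower number a stronger inhibitor), the highest of the three numbers in hand, though both companions sit within the scatter of it: compound 2 `Cc1cc(C)cc(NS(=O)(=O)c2ccc(N3CCNC3=O)cc2)c1` gives 400 nM and compound 3 `Cc1cccc(NS(=O)(=O)c2ccc(N3CCNC3=O)cc2)c1` gives 370 nM. The measured steps are a 1.8-fold lower number from compound 1 to compound 2 (0.24 log units; within the scatter), a 1.9-fold lower number from compound 1 to compound 3 (0.28 log units; within the scatter) and a 1.1-fold lower number from compound 2 to compound 3 (0.03 log units; within the scatter); none leaves the scatter. Compound 4 `CCc1cccc(NS(=O)(=O)c2ccc(N3CCNC3=O)cc2)c1` differs from compound 1 as follows: ethyl in place of methoxy on an aromatic carbon. The comparison that bears on this is a 1.9-fold lower number from compound 1 to compound 3 (0.28 log units; within the scatter), a methyl for the same methoxy; nothing measured here separates methyl from ethyl at that place. The step in this assay is therefore expected to be small, leaning toward a lower number, estimated as a 1.8-fold lower number from compound 1 to compound 4 (0.24 log units; within the scatter). For compound 4 the expected value is 400 nM, with a range from 180 nM to 900 nM.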

Compound 4, half-maximal inhibitory concentration: 450 nM
Beside the measured number, compound 4's estimate is 1.1-fold (0.05 log units) below it; the range from low to high includes it.
By their numbers in this assay, from the lowest: compounds 3, 2, 4 and 1 (each within the scatter of the next).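

In this assay the step to 3-ethylphenyl stays within the scatter from all three earlier aryl groups (a 1.6-fold lower number from compound 1 to compound 4 (0.19 log units; within the scatter); a 1.2-fold higher number from compound 3 to compound 4 (0.09 log units; within the scatter); a 1.1-fold higher number from compound 2 to compound 4 (0.05 log units; within the scatter)). Methoxy, methyl and ethyl are thus not separated at this place, and going from methyl to ethyl adds no step beyond the scatter. No measurement in hand gives a reason for this flat result.

From the compounds shown here alone, whether an amine, a carboxylic acid or a longer chain such as butyl at this place would leave the scatter stays open. So does whether the unsubstituted phenyl would differ from these compounds.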